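From 3-chlorophenyl to 4-methoxyphenyl in compound 3

The source may report more compounds than this note shows. Statements on the series, on what has been measured and on what is new or still open speak of the compounds shown alone.

In a functional assay on HepG2 cells (Homo sapiens) for antiproliferative activity, read by MTT assay, with a stated time of 72 h (on this read-out higher numbers stand for weaker inhibition and lower numbers for stronger inhibition), compound 1 `NC1=NC2(CCSCC2)N(OCCCOc2cccc(Cl)c2)C(N)=N1` gives 90 nM and compound 2 `NC1=NC2(CCOCC2)N(OCCCOc2cccc(Cl)c2)C(N)=N1` gives 150 nM with the two values within the usual scatter of each other. Among the compounds with values here, compound 1 therefore stands level with the only other measured number. Compound 3 `COc1ccc(OCCCON2C(N)=NC(N)=NC23CCSCC3)cc1` departs from compound 1 by one change, 4-methoxyphenyl in place of 3-chlorophenyl on an oxygen on a saturated carbon and this places 4-methoxyphenyl in place of 3-chlorophenyl on an oxygen on a saturated carbon. Within the data shown here, no measured pair tests a change at this place, so the expectation rests on the structural change alone. In this assay a modest move toward weaker inhibition is expected, with the estimated 2.2-fold higher number from compound 1 to compound 3 (0.35 log units; beyond the scatter) lying close to the edge of the scatter. For compound 3 the expected value is 200 nM with an estimated range from 60 nM to 650 nM until a measurement settles it.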

Compound 3, half-maximal inhibitory concentration: 880 nM
Estimate against measurement, compound 3: 4.4-fold (0.64 log units) below; the measured number lies above the stated range.
By their numbers in this assay, from the lowest: compounds 1 and 2 (each within the scatter of the next); then compound 3.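

In this assay, within the data shown here, the group on an oxygen on a saturated carbon clearly matters: 4-methoxyphenyl in place of 3-chlorophenyl gives a 9.8-fold higher number from compound 1 to compound 3 (0.99 log units; beyond the scatter), the only step so far between compounds that differ in one place. 3-Chlorophenyl and 4-methoxyphenyl differ in both the substituent and its ring number, so this one step cannot separate those two changes. Nothing available explains why the number rises at this position.

Still open, from the compounds shown here alone, is whether 4-chlorophenyl or 3-methoxyphenyl would separate the substituent from its ring number, and whether plain phenyl would sit nearer compound 1 or compound 3. Also open, going by these compounds, is whether 4-methoxyphenyl has the same effect on the core of compound 2, and how an amine or a carboxylic acid on the aromatic ring would read out.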